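The source may hold more compounds than are shown below. What is called first, only, known or untested is meant among the compounds shown, and "the series" means these compounds.

Compound 2, `CC/N=C(\S)OC[C@H]1OC(n2cnc3c(NC4CCOC4)ncnc32)[C@H](O)[C@@H]1O`, is the reference point of this small set. In an assay on DDT1 cells (Cricetulus griseus) for binding affinity to adenosine receptor A1 (Homo sapiens), read by radioligand binding (a higher number here means a weaker inhibitor, a lower number a stronger inhibitor), compound 2 gives 33 nM, the lowest of the three numbers measured, though none of the gaps to the other two lies beyond the scatter. Compound 1, `C/N=C(\S)OC[C@H]1OC(n2cnc3c(NC4CCOC4)ncnc32)[C@H](O)[C@@H]1O`, gives 45 nM in this assay, and compound 3, `CC/N=C(\S)OC[C@H]1OC(n2cnc3c(NC4CCOC4)nc(Cl)nc32)[C@H](O)[C@@H]1O`, gives 55 nM. The two single-point steps are accordingly small: a 1.4-fold lower number from compound 1 to compound 2 (0.13 log units; within the scatter), and a 1.7-fold higher number from compound 2 to compound 3 (0.22 log units; within the scatter). Both fall within the usual spread of repeated measurements.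

Compound 4, `CCCCNC(=O)OC[C@H]1OC(n2cnc3c(NC4CCOC4)ncnc32)[C@H](O)[C@@H]1O`, has not yet been measured in this assay. It differs from compound 2 by a group of 7 heavy atoms (5 carbon, 1 nitrogen, 1 oxygen; no ring) in place of a group of 5 heavy atoms (3 carbon, 1 nitrogen, 1 sulfur; no ring), on an oxygen on a saturated carbon. Within the data shown here, the only measured step touching the same part of the molecule is the one from compound 1 to compound 2, and that step stayed within the scatter; the step to compound 3 concerns a different position. Nothing measured here speaks for a large shift in either direction, so the expectation for compound 4 is a number close to that of compound 2, with a 1.5-fold higher number from compound 2 to compound 4 (0.18 log units; within the scatter) expected to lie within the scatter. Compound 4 is therefore estimated at 50 nM in this assay, expected to fall between 18 nM and 140 nM.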

Compound 4, inhibition constant: 1410 nM
Compound 4: middle estimate off by 28-fold (1.45 log units), on the low side; measured number outside the range, above it.
By their numbers in this assay, from the lowest: compounds 2, 1 and 3 (each within the scatter of the next); then compound 4.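

At the oxygen on a saturated carbon, the earlier compounds had shown only a small change within the scatter, a 1.4-fold lower number from compound 1 to compound 2 (0.13 log units; within the scatter) in this assay, and this position now proves far from indifferent. Putting butylcarbamoyl in place of the group carried by compound 2 gives a 43-fold higher number from compound 2 to compound 4 (1.63 log units; beyond the scatter) and, set against the smaller group of compound 1, the same kind of replacement gives a 31-fold higher number from compound 1 to compound 4 (1.50 log units; beyond the scatter) in the same assay, so both steps lie beyond the scatter and point the same way. The counts of hydrogen-bond donors and acceptors are the same on the two sides of the change, and no net charge appears on either side, so these counted features do not distinguish the groups that gave so different a result.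

The compounds shown leave open whether the large step goes with the carbonyl oxygen in place of sulfur or with the butyl chain, since the two changes arrive together and neither a butyl chain on the sulfur-bearing group nor a shorter chain on the carbamoyl group stands among them. Nothing given here bears on the cause of this step.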